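This account rests on a few compounds, and the source may have more. Where it says the series, first, only, none or still open, it means among the compounds named here.

Within the data shown here, in a functional assay on the whole organism (strain Sprague-Dawley) for inhibition, with Rattus norvegicus as the target, with a stated time of 10 min (on this read-out higher numbers stand for an effect only at larger amounts of compound and lower numbers for an effect already at smaller amounts), compound 1 `O=C(O)c1cnc(-c2ccccc2F)[nH]c1=O` gives 5 mg/kg, the only exact number so far. Compound 2 `O=C(O)c1cnc(-c2ccccc2[N+](=O)[O-])[nH]c1=O` gives only a limit, > 50 mg/kg. Compound 3 `O=C(O)c1cnc(-c2ccccc2O)[nH]c1=O` also gives only a limit, > 5 mg/kg. Compound 4 `COc1ccccc1-c1ncc(C(=O)O)c(=O)[nH]1` alters compound 1 in one place: methoxy in place of fluoro on an aromatic carbon. This puts methoxy in place of fluoro on an aromatic carbon, ortho to a large group. Two measured replacements of that fluoro bear on it. Nitro gave an at least 10-fold higher number from compound 1 to compound 2 (1.00 log units; beyond the scatter), while hydroxy gave a number no lower from compound 1 to compound 3 (the limit leaves the size open). Neither replacement lowered the number, so a move to a higher number is expected in this assay, estimated as a 2.4-fold higher number from compound 1 to compound 4 (0.38 log units; beyond the scatter). For compound 4 the estimated value is 12 mg/kg, with an expected range from 3 mg/kg to 50 mg/kg.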

Compound 4, dose for 50% inhibition: 10 mg/kg
Compound 4: middle estimate off by 1.2-fold (0.08 log units), on the high side, within the range that was stated.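

Methoxy in place of fluoro at this aromatic position gives a 2.0-fold higher number from compound 1 to compound 4 (0.30 log units; within the scatter) in this assay and is the first replacement of that fluoro here with an exact number. Methoxy in place of nitro gives an at least 5.0-fold lower number from compound 2 to compound 4 (0.69 log units; beyond the scatter) and shows that a replacement at this position need not cost as much as nitro did. The step between compound 3 and compound 4 cannot be read, as compound 3 holds only a limit: the limit of > 5 mg/kg in this assay, at which 1 of the 4 values shown sits.

From the compounds shown here alone, how an amine, a chlorine atom or a longer ether chain would behave at this position remains open.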